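The source may report more compounds than this note shows. Statements on the series, on what has been measured and on what is new or still open speak of the compounds shown alone.

Of the compounds shown here, two have numbers so far. Compound 1 `O/N=C(/Nc1cccc(Br)c1)c1ccc2occc2c1` in an assay on tissue (HeLa cells) for inhibition of Indoleamine 2,3-dioxygenase 1 (Homo sapiens), read by spectrophotometry (a lower number here means a stronger inhibitor, a higher number a weaker inhibitor), gives 1100 nM. Compound 2 `COCc1cc2cc(/C(=N\O)Nc3cccc(F)c3)ccc2o1` in this assay gives 6100 nM, the highest of the two values shown, and the gap to compound 1 lies beyond the scatter. Compound 3 `COCc1cc2cc(/C(=N\O)Nc3cccc(Br)c3)ccc2o1` is not yet measured; it differs from compound 2 by bromo in place of fluoro on an aromatic carbon. Within the data shown here, no directly comparable pair exists to size this swap, so the expected step from compound 2 to compound 3 is taken as a modest decrease, a 2.0-fold lower number from compound 2 to compound 3 (0.31 log units; beyond the scatter), with wide uncertainty. The estimate for compound 3 is therefore 3000 nM, spanning 1200 nM to 8000 nM.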

Compound 3, half-maximal inhibitory concentration: 2500 nM
Compound 3: middle estimate off by 1.2-fold (0.08 log units), on the high side, within the range that was stated.
By their numbers in this assay, from the lowest: compound 1; then compound 3; then compound 2.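

In this assay the change from 3-fluorophenyl to 3-bromophenyl gives a 2.4-fold lower number from compound 2 to compound 3 (0.39 log units; beyond the scatter) with methoxymethyl held in place, so this position responds to the choice of halogen, and bromo gives the lower number. With bromo held constant, methoxymethyl in place of hydrogen gives a 2.3-fold higher number from compound 1 to compound 3 (0.36 log units; beyond the scatter) and can now be sized on its own, which compounds 1 and 2, differing in two places, did not allow. Nothing at hand gives a reason for either step.

As far as these compounds go, whether the bromo-over-fluoro difference persists without methoxymethyl remains open. So does the outcome with chloro or an amine on this ring, or with a longer ether chain in place of methoxymethyl.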